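A few compounds are considered here, and "the series" means these few. Any claim that something is new, unique, unknown or untested is made for them only; others in the source may bear on it.

Compound 1 `ClCc1cccc(Cn2cnc3c(Cl)ncnc32)c1` gives 5750 nM in a functional assay on OVCAR-4 cells (Homo sapiens) for cytotoxicity, read by sulforhodamine B assay, with a stated time of 48 h; on this read-out higher numbers stand for weaker inhibition of growth and lower numbers for stronger inhibition of growth. Compound 2 `ClCc1cccc(Cn2cnc3c(Cl)nc(Cl)nc32)c1` differs from compound 1 by chloro in place of hydrogen on an aromatic carbon, and in this assay compound 2 gives 20000 nM; the step is a 3.5-fold higher number from compound 1 to compound 2 (0.54 log units; beyond the scatter). Compound 3 `ClCc1ccccc1Cn1cnc2ncnc(Cl)c21` has the same atoms as compound 1 joined differently; the difference between the two cores is not broken down here. In this assay compound 3 gives 20400 nM, and compound 2 and compound 3 sit within the scatter of each other, while compound 3 stands beyond the scatter from compound 1.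

Compound 4 `ClCc1ccccc1Cn1cnc2nc(Cl)nc(Cl)c21` is not yet measured. Among the measured compounds shown here, it differs from compound 3 by chloro in place of hydrogen on an aromatic carbon, the same change as the one from compound 1 to compound 2, at the same place on the core. A step in the same direction is expected, a 2.5-fold higher number from compound 3 to compound 4 (0.39 log units; beyond the scatter), because on the other core the same change gave a 3.5-fold higher number from compound 1 to compound 2 (0.54 log units; beyond the scatter). A single precedent is a thin basis, so the range is kept wide. Compound 4 is therefore expected to give about 50000 nM in this assay, estimated to lie from 20000 nM to 120000 nM.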

Compound 4, concentration for total growth inhibition: 5120 nM
Compound 4: middle estimate off by 9.8-fold (0.99 log units), on the high side; measured number below the stated range.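

Set on the core of compound 3, chloro in place of hydrogen on an aromatic carbon between two ring nitrogen atoms gives a 4.0-fold lower number from compound 3 to compound 4 (0.60 log units; beyond the scatter) in this assay, which runs opposite to the earlier step on the core of compound 1. The two steps differ by more than the scatter allows: the same change on two cores in this assay, a 3.5-fold higher number (0.54 log units; beyond the scatter) from compound 1 to compound 2 and a 4.0-fold lower number (0.60 log units; beyond the scatter) from compound 3 to compound 4, 14-fold (1.14 log units) apart, beyond the scatter of two such steps. The size and direction of this change therefore do not carry from one core to the other in this series, though with a single pair per core and a single assay, this shows neither why they part nor how the change would behave on any further core, and the difference between the two cores is not broken down.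

Open, from the compounds shown here alone, is whether an amine on that same aromatic carbon, in place of the chloro, would also give opposite steps on the two cores. Also open, going by these compounds, is whether a hydroxymethyl group in place of the chloromethyl group would leave the split between the cores intact.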